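Chloro for Trifluoromethyl in a Boron-Bearing Chalcone

The compounds below may be only part of what the source reports. "The series", "measured", "known", "first", "only" and "open" are said of these compounds alone.

Of the compounds shown here, two have so far been tested for harm to cultured mouse cells in an ADME assay on L929 cells (Mus musculus) for cytotoxicity, read by resazurin assay, with a stated time of 72 h; on this read-out lower numbers stand for stronger inhibition and higher numbers for weaker inhibition. Compound 1 `COc1cc(C(=O)/C=C/c2ccc3c(c2)B(O)OC3)cc(OC)c1OC` gives > 10 ug/mL in this assay, a limit of the assay rather than a measured number. Compound 2 `O=C(/C=C/c1ccc2c(c1)B(O)OC2)c1ccc(C(F)(F)F)cc1` gives > 10 ug/mL in this assay, again only a limit. Both results sit at the same point: the limit of > 10 ug/mL in this assay, at which 2 of the 2 values shown sit. For the measured compounds named here, compound 2 therefore stands exactly where every value so far stands, and nothing yet separates it from compound 1. Compound 3 `O=C(/C=C/c1ccc2c(c1)B(O)OC2)c1ccc(Cl)cc1` has not been measured. It differs from compound 2 in one place: chloro in place of trifluoromethyl on an aromatic carbon. Going by the values given here, no completed step of this kind exists to lean on, so the expected step is small, none beyond the usual scatter: a step that the limit leaves unreadable from compound 2 to compound 3. Compound 3 is estimated at 15 ug/mL in this assay, within a range from 8 ug/mL to 40 ug/mL, and most likely the assay will again report only a limit.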

Compound 3, half-maximal inhibitory concentration: > 10 ug/mL
Compound 3 was reported as a limit; the forecaster's own chance of this, stated with the estimate: 80%; the middle value lies beyond the limit too.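

Compound 2 and compound 3 both end at a limit rather than a number, so no step can be read between them: the limit of > 10 ug/mL in this assay, at which 3 of the 3 values shown sit.

The compounds shown leave open how strongly any of them harms these cells, and whether chloro in place of trifluoromethyl changes that at all.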